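Chloro on the phenyl of compound 2

A few compounds are considered here, and "the series" means these few. Any claim that something is new, unique, unknown or untested is made for them only; others in the source may bear on it.

In a functional assay (microsomes, liver) with Rattus norvegicus as the target (on this read-out higher numbers stand for weaker inhibition and lower numbers for stronger inhibition), compound 1 (`Cc1c(C)c2c(c(C)c1N)CC(C)(C)O2`) gives 760 nM as its value, and compound 2 (`Cc1c(C)c2c(c(C)c1Nc1ccccc1)CC(C)(C)O2`) gives 280 nM as its value. Going by the values given here, compound 2 therefore holds the lower of the two numbers so far, which on this read-out means stronger inhibition.

Compound 3 (`Cc1c(C)c2c(c(C)c1Nc1ccc(Cl)cc1)CC(C)(C)O2`) differs from compound 2 at one place on its phenyl ring: chloro in place of hydrogen on an aromatic carbon ( chloro in place of hydrogen on an aromatic carbon ).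

Among the compounds with values here, only one measured step bears on this change. That step, with phenyl in place of hydrogen on a nitrogen on an aromatic ring, is a 2.7-fold lower number from compound 1 to compound 2 (0.43 log units; beyond the scatter) and it counts as modest. Within the data shown here, it added a whole ring, whereas the new change adds a single atom, and no measured compound yet carries a group on that phenyl. Going by the modest size of that step between compound 1 and compound 2, only a small shift towards a lower number is expected, one that stays within the usual scatter. The expected step is a 1.2-fold lower number from compound 2 to compound 3 (0.09 log units; within the scatter) on this estimate. Compound 3 is estimated at 230 nM with an expected range from 100 nM to 520 nM in this assay when it is measured.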

Compound 3, half-maximal inhibitory concentration: 300 nM
Beside the measured number, compound 3's estimate is 1.3-fold (0.12 log units) below it; measured number inside the range.
By their numbers in this assay, from the lowest: compounds 2 and 3 (each within the scatter of the next); then compound 1.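

In this assay the chloro group gives a 1.1-fold higher number from compound 2 to compound 3 (0.03 log units; within the scatter), so a single chlorine in place of hydrogen at this place on the phenyl, para to a large group, leaves the number within the scatter of the unsubstituted compound. This is also the first view of a phenyl that carries a group of its own, and the lower number that came with adding a phenyl to the nitrogen is kept: the 4-chlorophenyl group in place of hydrogen gives a 2.5-fold lower number from compound 1 to compound 3 (0.40 log units; beyond the scatter), which reads much like a 2.7-fold lower number from compound 1 to compound 2 (0.43 log units; beyond the scatter). Nothing measured on these compounds offers an explanation for this result.

From the compounds shown here alone, one chlorine at one ring position is a narrow test, so it remains open whether a larger or very different group at the same place, such as methoxy, an amine or a carboxylic acid, would also leave the number unmoved. Also open, going by these compounds, is whether chloro on another carbon of the phenyl would behave as it does here, and whether a second substituent on the ring would change the picture.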